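Compound 3 and the limit of the assay

The source may report more compounds than this note shows. Statements on the series, on what has been measured and on what is new or still open speak of the compounds shown alone.

Measured in a functional assay on SK-MEL-5 cells (Homo sapiens) for inhibition, read by sulforhodamine B assay, with a stated time of 48 h; on this read-out higher numbers stand for lower toxicity in this test and lower numbers for higher toxicity in this test:
Compound 1 `Cc1ccc(C2=NN(c3ccc(S(C)(=O)=O)cc3)C(=O)CC2)cc1`: > 100000 nM, a limit of the assay
Compound 2 `Cc1cc(O)ccc1C1=NN(c2ccc(S(C)(=O)=O)cc2)C(=O)CC1`: > 100000 nM, a limit of the assay

Compound 2 shows only a limit, > 100000 nM. Neither measured compound gives a number, and both sit at the same point: the limit of > 100000 nM in this assay, at which 2 of the 2 values shown sit.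

The next compound is compound 3 `CCc1ccc(C2=NN(c3ccc(S(C)(=O)=O)cc3)C(=O)CC2)cc1`, which carries 4-ethylphenyl in place of 4-hydroxy-2-methylphenyl on a carbon with a double bond to nitrogen.

For the measured compounds named here, one measured step bears on this change, since it alters the group at the same place: a step that the two limits leave unreadable from compound 1 to compound 2. It offers no size to carry over, so no readable step and no direction can be expected in this assay. The expected outcome is a number no higher from compound 2 to compound 3 (the limit leaves the size open). Compound 3 is estimated at 100000 nM, within an expected range of 50000 nM to 200000 nM, and a further limit is the likeliest report.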

Compound 3, concentration lethal to 50% of the cells: 35700 nM
Compound 3: the middle estimate sits 2.8-fold (0.45 log units) above what was measured; measured number outside the range, below it.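

In this assay, this position on the carbon with a double bond to nitrogen now gives a readable response: 4-ethylphenyl in place of 4-methylphenyl gives an at least 2.8-fold lower number from compound 1 to compound 3 (0.44 log units; beyond the scatter), so one added methyl on the saturated chain carbon bound to an aromatic carbon is enough to bring a number into the range of the test. 4-ethylphenyl in place of 4-hydroxy-2-methylphenyl gives an at least 2.8-fold lower number from compound 2 to compound 3 (0.44 log units; beyond the scatter), although this change does not separate the hydroxy group from the ring methyl. Both steps give only a minimum size because the starting compounds carry no number: the limit of > 100000 nM in this assay, at which 2 of the 3 values shown sit.

As far as these compounds go, whether a longer chain such as propyl would lower the number further remains open. An amine or a carboxylic acid on the phenyl ring at this position is also untested in the compounds shown.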